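Chloro Substitution Read Across Two Shared Cores

The source may report more compounds than this note shows. Statements on the series, on what has been measured and on what is new or still open speak of the compounds shown alone.

Compound 1 `CS(=O)(=O)c1ccc(Nc2ncc(F)c(Nc3nc4ccccc4s3)n2)cc1`: 6880 nM
Compound 2 `Cc1cnc(Nc2ccc(S(N)(=O)=O)cc2)nc1Nc1nc2ccccc2s1`: > 50000 nM
Compound 3 `CS(=O)(=O)c1ccc(Nc2ncc(F)c(Nc3nc4ccc(Cl)cc4s3)n2)cc1`: > 50000 nM

All three were tested in a functional assay on MCF7 cells (Homo sapiens) for antiproliferative activity, read by MTT assay, with a stated time of 48 h; on this read-out lower numbers stand for stronger inhibition and higher numbers for weaker inhibition. Compound 1 gives 6880 nM. For compound 2 the reported > 50000 nM is a limit of the assay, not a number. For compound 3 the reported > 50000 nM is likewise a limit. Compound 1 and compound 3 differ in one place, (chloro in place of hydrogen on an aromatic carbon), and that single change produced an at least 7.2-fold higher number from compound 1 to compound 3 (0.86 log units; beyond the scatter). Compound 1 and compound 2 have different cores; the difference between the two cores is not broken down here.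

Compound 4 `Cc1cnc(Nc2ccc(S(N)(=O)=O)cc2)nc1Nc1nc2ccc(Cl)cc2s1` has not yet been measured. It stands to compound 2 as compound 3 stands to compound 1: chloro in place of hydrogen on an aromatic carbon. The place of the change is described in the same words in both pairs, so this is the same change made on a second core.

Since compound 2 already sits at the limit of > 50000 nM in this assay, at which 2 of the 3 values shown sit, and the same change once gave an at least 7.2-fold higher number from compound 1 to compound 3 (0.86 log units; beyond the scatter), compound 4 is expected to return only a limit again, the estimate being 120000 nM with an expected step that the limit leaves unreadable from compound 2 to compound 4. Whether the assay can still resolve a number for compound 4 is what the measurement will show.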

Compound 4, half-maximal inhibitory concentration: 8430 nM
The estimate for compound 4 lay 14-fold (1.15 log units) above the measured number; measured number below the stated range.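

Chloro in place of hydrogen on an aromatic carbon did not act alike on the two cores in this assay. On the core of compound 2 it gave an at least 5.9-fold lower number from compound 2 to compound 4 (0.77 log units; beyond the scatter), the opposite direction from the step on the core of compound 1: the same change on two cores in this assay, an at least 7.2-fold higher number (0.86 log units; beyond the scatter) from compound 1 to compound 3 and an at least 5.9-fold lower number (0.77 log units; beyond the scatter) from compound 2 to compound 4, at least 43-fold (1.63 log units) apart, beyond the scatter of two such steps. Each of the two steps has one end at a limit of the assay, so their true sizes stay unknown, and this shows only that the direction cannot be assumed to carry over, not why it reversed or what would happen on a third core: the limit of > 50000 nM in this assay, at which 2 of the 4 values shown sit.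

The two cores differ in more than one place, so the compounds shown leave open which of those differences decides the direction of the step. Also open, on these data alone, is how a different group on the same carbon, such as a methoxy group or an amine, would behave on each core.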